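Swapping Acetyl for Benzoyl

This account rests on a few compounds, and the source may have more. Where it says the series, first, only, none or still open, it means among the compounds named here.

Within the data shown here, in a physicochemical assay for lipophilicity, read by HPLC, measured as chromatographic lipophilicity, at pH 7.4 (a higher number here means a more lipophilic compound, a lower number a more polar compound), compound 1 `CC(=O)N1CCC(C(=O)N2N=CCC2c2ccccc2)CC1` gives 2.5 and stands lowest of the two numbers so far. Compound 2 `O=C(C1CCN(c2ncccn2)CC1)N1N=CC[C@H]1c1ccccc1` gives 4.7 and lies higher by a gap beyond the scatter of repeat measurements. Compound 3 `O=C(c1ccccc1)N1CCC(C(=O)N2N=CCC2c2ccccc2)CC1` is still unmeasured. It keeps the core of compound 1 and changes in one place by phenyl in place of methyl on a carbonyl carbon with phenyl in place of methyl on a carbonyl carbon, a change from acetyl to benzoyl. Among the measured compounds shown here, no measured pair shows this swap directly, so the expected rise in this assay is only an estimate, a number 1.10 log units higher from compound 1 to compound 3 (beyond the scatter) upward and beyond the scatter. Compound 3 is expected at 3.6 within an estimated range of 3.1 to 4.2 once measured.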

Compound 3, distribution coefficient: 4.4
Compound 3: the middle estimate sits 0.80 log units below what was measured; the measured number lies above the stated range.
By their numbers in this assay, from the lowest: compound 1; then compounds 3 and 2 (each within the scatter of the next).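

On a carbonyl carbon whose other neighbour is an amide-type nitrogen in a ring, phenyl in place of methyl gives, in this assay, a number 1.90 log units higher from compound 1 to compound 3 (beyond the scatter). Among these compounds, this is the first measured pair to isolate that swap, so the step can be read directly, with the rest of the core of compound 1 unchanged. Nothing available explains the size of this step. On these data alone, what a longer chain such as butyl or an amine would read on this carbonyl carbon stays open. One pair also cannot show whether the same swap would give a similar step on another core.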